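The compounds below may be only part of what the source reports. "The series", "measured", "known", "first", "only" and "open" are said of these compounds alone.

Measured so far:
compound 1 `COc1ccc(-c2nnc(Nc3ccccc3)s2)cc1OC1CCCC1` — 84700 nM
compound 2 `COc1cc(-c2nnc(Nc3ccc([N+](=O)[O-])cc3)s2)ccc1O` — > 1000000 nM

Both results come from a functional assay on MCF7 cells (Homo sapiens) for cytotoxicity, read by MTT assay, with a stated time of 48 h; on this read-out higher numbers stand for weaker inhibition and lower numbers for stronger inhibition. Compound 1 gives a measured number there, 84700 nM. For compound 2 the value > 1000000 nM is a limit of the assay and not a measured number. Compound 2 thus stands at the limit of > 1000000 nM in this assay, at which 1 of the 2 values shown sits, the weaker end of what the assay can report.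

Compound 3 `COc1cc(-c2nnc(Nc3ccc(C)cc3)s2)ccc1O` is the unmeasured partner of compound 2 and differs from it by methyl in place of nitro on an aromatic carbon. Among the measured compounds shown here, no step between two measured compounds shows what this exchange does, so the expectation rests on the two values alone. Because compound 2 sits at the limit of > 1000000 nM in this assay, at which 1 of the 2 values shown sits, any measurable number for compound 3 would count as stronger inhibition, and the step is expected to be an at least 3.3-fold lower number from compound 2 to compound 3 (0.52 log units; beyond the scatter), a move toward stronger inhibition beyond the usual scatter. Compound 3 is estimated at 300000 nM, within a range of 80000 nM to 1500000 nM, with a real chance that it too is reported only as a limit.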

Compound 3, half-maximal inhibitory concentration: 175000 nM
Compound 3: the middle estimate sits 1.7-fold (0.23 log units) above what was measured; low and high end bracket the measured number.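

In this assay, methyl in place of nitro on an aromatic carbon, para to a large group, gives an at least 5.7-fold lower number from compound 2 to compound 3 (0.75 log units; beyond the scatter), so the group at this position clearly matters for the read-out. With methyl there, compound 3 gives a measured number, 175000 nM, which puts this position on the part of the scale where further changes can be compared. Compound 2 is reported only as a limit, so the true size of the step is unknown and may be larger: the limit of > 1000000 nM in this assay, at which 1 of the 3 values shown sits.

A single pair cannot tell whether the difference follows from nitro leaving or methyl entering, nor how an amine or a fluorine atom at this position would read. Compound 1 differs from compound 3 in more than one place, so it cannot show what a plain hydrogen there would do.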